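The compounds below may be only part of what the source reports. "The series", "measured", "known", "first", "only" and "open" are said of these compounds alone.

Compound 1 `CCNC(=O)c1nc(-c2cc(OC)c(OC)c(OC)c2)n(-c2ccc(OC)cc2)n1` gave 60%
Compound 2 `COc1ccc(-n2nc(C(=O)Nc3cccc(F)c3)nc2-c2cc(OC)c(OC)c(OC)c2)cc1` gave 48%

Among the compounds with values here, in a functional assay on the whole organism for inhibition, with Rattus norvegicus as the target, read by paw edema, with stated times of 30 min and 1 h, at a dose of 0.28 mmol/kg by the oral route (on this read-out higher numbers stand for more inhibition at the one dose given (going by the name of the read-out) and lower numbers for less inhibition), compound 1 stands highest of the two numbers; the only neighbour, compound 2, lies lower by a number 12 percentage points lower from compound 1 to compound 2 (beyond the scatter). Compound 3 `COc1ccc(-n2nc(C(=O)Nc3ccc(O)cc3)nc2-c2cc(OC)c(OC)c(OC)c2)cc1` differs from compound 1 by 4-hydroxyphenyl in place of ethyl on an amide-type nitrogen. Within the data shown here, the single step that bears on this is a number 12 percentage points lower from compound 1 to compound 2 (beyond the scatter), where the same ethyl gave way to another aryl group on that amide-type nitrogen. A drop of roughly the same size is therefore expected for compound 3, namely a number 10 percentage points lower from compound 1 to compound 3 (within the scatter). Compound 3 is estimated at 50%, within a range of 35% to 65%.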

Compound 3, a percentage reported as inhibition, in the whole organism at one dose (the size of the read-out at that dose, not a potency): 36%
Beside the measured number, compound 3's estimate is 14 percentage points above it, within the range that was stated.
By their numbers in this assay, from the lowest: compound 3; then compound 2; then compound 1.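

In this assay a second aryl group on the amide-type nitrogen also falls short of ethyl, with a number 24 percentage points lower from compound 1 to compound 3 (beyond the scatter). The substituent on that aryl group matters as well, since the data show a number 12 percentage points lower from compound 2 to compound 3 (beyond the scatter), so 4-hydroxyphenyl and 3-fluorophenyl are not interchangeable at this place. Nothing available explains either step. The compounds shown leave open whether a longer alkyl chain such as propyl would match or exceed ethyl. They also leave open how an unsubstituted phenyl or a methoxy-bearing phenyl would compare with these two aryl groups.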